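The compounds below may be only part of what the source reports. "The series", "measured", "known", "first", "only" and "open" are said of these compounds alone.

Measured compounds in the series:

compound 1 `Cc1cccc2c1nc(COc1ccc(Cl)cc1)n2CCCC1CCN(C)CC1`: 52 nM
compound 2 `Cc1cccc2c1nc(COc1ccc(Cl)cc1)n2CCCC1CCN(CC(=O)O)CC1`: 2190 nM
compound 3 `Cc1cccc2c1nc(COc1ccc(Cl)cc1)n2CCCC1CCN(CCCC(N)=O)CC1`: 88 nM

In an assay on AV12 cells for binding affinity to Neuropeptide Y receptor type 1 (Homo sapiens) (on this read-out lower numbers stand for stronger inhibition and higher numbers for weaker inhibition), compound 1 gives the lowest number of the three. Compound 3 lies within the scatter of it, a 1.7-fold higher number from compound 1 to compound 3 (0.23 log units; within the scatter), while compound 2 is well apart, a 42-fold higher number from compound 1 to compound 2 (1.62 log units; beyond the scatter); between those two, a 25-fold lower number from compound 2 to compound 3 (1.40 log units; beyond the scatter).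

Compound 4 `Cc1cccc2c1nc(COc1ccc(Cl)cc1)n2CCCC1CCN(C(=O)CCN2CCCCC2)CC1` is not yet measured. Its change from compound 1 is (2-(piperidin-1-yl)ethyl)carbonyl in place of methyl on an amine nitrogen in a ring.

For the measured compounds named here, no measured step makes this exact change. The two steps from compound 1 bear on it only loosely: a carboxy group on the chain carbon bound to that ring nitrogen cost a large step, a 42-fold higher number from compound 1 to compound 2 (1.62 log units; beyond the scatter), whereas a 2-carbamoylethyl group at the same place stayed within the scatter, a 1.7-fold higher number from compound 1 to compound 3 (0.23 log units; within the scatter). Compound 4 carries a carbonyl directly on the ring nitrogen and a further ring, so a modest loss is expected rather than a large one, an expected step of a 2.9-fold higher number from compound 1 to compound 4 (0.46 log units; beyond the scatter).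

Compound 4 is therefore estimated at 150 nM in this assay, with a range from 40 nM to 600 nM.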

Compound 4, inhibition constant: 260 nM
For compound 4 the middle estimate is 1.7-fold (0.24 log units) below the measured one, and the stated range covers the measured number.
By their numbers in this assay, from the lowest: compounds 1 and 3 (each within the scatter of the next); then compound 4; then compound 2.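

Placing (2-(piperidin-1-yl)ethyl)carbonyl on the amine nitrogen in a ring puts a carbonyl directly on that nitrogen and adds a further six-membered non-aromatic ring, yet in this assay the cost over methyl stays modest (a 5.0-fold higher number from compound 1 to compound 4 (0.70 log units; beyond the scatter)). The same group lies beyond the scatter in both directions from the other two substituents: it gives a higher number than 3-carbamoylpropyl (a 3.0-fold higher number from compound 3 to compound 4 (0.47 log units; beyond the scatter)) and a lower number than carboxymethyl (an 8.4-fold lower number from compound 2 to compound 4 (0.93 log units; beyond the scatter)). No available evidence accounts for this order.

The contributions of the carbonyl and the piperidine ring remain unseparated. A 3-(piperidin-1-yl)propyl group, which lacks the carbonyl, and a plain acetyl group, which lacks the ring, would each test one part at this nitrogen.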